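From 2-Hydroxyphenyl to 3-Hydroxyphenyl: One Small Structural Change

A few compounds are considered here, and "the series" means these few. Any claim that something is new, unique, unknown or untested is made for them only; others in the source may bear on it.

In a physicochemical assay for lipophilicity, read by HPLC, measured as octanol-water partition (a higher number here means a more lipophilic compound, a lower number a more polar compound), compound 1 `O=C(N/N=C/c1ccc2no[n+]([O-])c2c1)c1ccccc1O` stands at 1.3 and shares the highest of the three measured numbers. Compound 3 `NC(=O)c1c(COc2ccc(/C=N/NC(=O)c3ccncc3)cc2)no[n+]1[O-]` gives 1.3 here, level with compound 1 within the scatter. Compound 2 `O=C(N/N=C/c1ccc2no[n+]([O-])c2c1)c1ccc([N+](=O)[O-])cc1` gives 0.9 as a number lower than compound 1 beyond the scatter. Compound 4 `O=C(N/N=C/c1ccc2no[n+]([O-])c2c1)c1cccc(O)c1` is not yet measured. It has 3-hydroxyphenyl in place of 2-hydroxyphenyl on a carbonyl carbon and keeps the same atoms, joined differently. Among the compounds with values here, no measured pair shows such a change, so in this assay only a small downward step is expected, none beyond the scatter. The expected move is a number 0.20 log units lower from compound 1 to compound 4 (within the scatter) and it remains an estimate. For compound 4 the estimated value is 1.1 with an expected range from 0.7 to 1.5 around it.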

Compound 4, partition coefficient: 1.2
For compound 4 the middle estimate is 0.10 log units below the measured one; the measured number falls inside the stated range.
By their numbers in this assay, from the lowest: compounds 2, 4, 1 and 3 (each within the scatter of the next, the first and the last beyond it).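

Placing 3-hydroxyphenyl in place of 2-hydroxyphenyl on a carbonyl carbon, with the same atoms joined differently, gives a number 0.10 log units lower from compound 1 to compound 4 (within the scatter) in this assay. This pair is the first among the compounds shown to differ in one place, so it gives the first direct reading at this position: the change leaves no step that can be told apart from the scatter. Nothing measured here explains this result.

This single pair keeps the hydroxyl group throughout. On these data alone, how an amine or a carboxylic acid at this position would read in this assay remains open.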